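Removing the Methyl Group from a Weakly Inhibiting Series

The compounds below may be only part of what the source reports. "The series", "measured", "known", "first", "only" and "open" are said of these compounds alone.

Compound 1, `N#Cc1ccc(-c2cnc3[nH]cc(-c4nnc(-c5ccc(Cl)cc5)o4)c(=O)c3c2)cc1`, gives 4.65% in a functional assay on MCF7 cells (Homo sapiens) for inhibition, read by MTT assay, with a stated time of 24 h, tested at 5 uM; on this read-out higher numbers stand for more inhibition of growth at the one concentration tested and lower numbers for less inhibition of growth.
Compound 2, `CS(=O)(=O)c1ccc(-c2cnc3[nH]cc(-c4nnc(-c5ccc(F)cc5)o4)c(=O)c3c2)cc1`, gives 3.78%.
Compound 3, `Cc1ccc(-c2nnc(-c3c[nH]c4ncc(-c5ccc(S(C)(=O)=O)cc5)cc4c3=O)o2)cc1`, gives 6.26%.

All three compounds share one core and differ only in the substituent on the pendant phenyl ring. Under this assay none of them inhibits growth to a meaningful degree: compound 3 stands alongside compound 1 and compound 2, and none of the three numbers lies apart from another by more than the scatter. Among the compounds with values here, the only single-point step among them, a number 2.5 percentage points higher from compound 2 to compound 3 (within the scatter), shows that exchanging one small para substituent for another leaves the read-out where it was.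

Compound 4, `CS(=O)(=O)c1ccc(-c2cnc3[nH]cc(-c4nnc(-c5ccccc5)o4)c(=O)c3c2)cc1`, takes one further step from compound 3: hydrogen in place of methyl on an aromatic carbon. Within the data shown here, the one measured step that bears on this change is the exchange of fluoro for methyl at the same place, and it was within the scatter. A change from methyl to hydrogen at that position is therefore expected to give no step beyond the scatter either; the estimated step is a number 1.8 percentage points lower from compound 3 to compound 4 (within the scatter), with no direction claimed. Compound 4 is estimated to give 4.5%, in a range from -3% to 12%.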

Compound 4, percent growth inhibition at one concentration: 1.38%
Compound 4: middle estimate off by 3.1 percentage points, on the high side, and the stated range covers the measured number.
By their numbers in this assay, from the lowest: compounds 4, 2, 1 and 3 (each within the scatter of the next).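

In this assay, removing the methyl group gives a number 4.9 percentage points lower from compound 3 to compound 4 (within the scatter), and removing the fluoro group gives a number 2.4 percentage points lower from compound 2 to compound 4 (within the scatter). Compound 4 adds the case of no substituent at all at this place, para to a large group, so the comparison now runs from 4-methylphenyl and the fluoro-substituted ring to plain phenyl, and across these three compounds the read-out does not separate any of the three occupants. No measurement is available that would explain this flat result or say anything about what the position does in the cells.

Still open, from the compounds shown here alone, is whether an amine, a carboxylic acid, a methoxy group or a longer alkyl chain at this place would move growth inhibition clear of the scatter, since methyl, fluoro and hydrogen span only a narrow choice of small groups. Compound 1 differs from the others in two places, with chloro on one ring and nitrile on the other, so the nitrile cannot be weighed on its own against the methylsulfonyl group of compound 2, compound 3 and compound 4.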